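Indazole substitution on the triaryl acrylic acid series

The source may hold more compounds than are shown below. What is called first, only, known or untested is meant among the compounds shown, and "the series" means these compounds.

Measured compounds:
compound 1 `CC/C(=C(/c1ccc(/C=C/C(=O)O)cc1)c1ccc2[nH]ncc2n1)c1ccccc1`, 33 nM
compound 2 `CC/C(=C(/c1ccc(/C=C/C(=O)O)cc1)c1cc2cn[nH]c2cc1C)c1ccccc1`, 468 nM
compound 3 `CC/C(=C(/c1ccc(/C=C/C(=O)O)cc1)c1ccc2[nH]ncc2c1F)c1ccccc1`, 3 nM

In a functional assay on MCF7 cells (Homo sapiens) for cytotoxicity, read by CellTiter-Glo, with a stated time of 5 days (on this read-out higher numbers stand for weaker inhibition and lower numbers for stronger inhibition), compound 3 gives 3 nM, the lowest number of the three. The step to it from the pyrazolopyridine analogue is an 11-fold lower number from compound 1 to compound 3 (1.04 log units; beyond the scatter), and the step from the methyl-substituted indazole is a 160-fold lower number from compound 2 to compound 3 (2.19 log units; beyond the scatter); both are large, and the step of a 14-fold higher number from compound 1 to compound 2 (1.15 log units; beyond the scatter) shows that changing which group sits on the double-bonded chain carbon swings this assay widely.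

Compound 4 `CC/C(=C(/c1ccc(/C=C/C(=O)O)cc1)c1cc(Cl)c2[nH]ncc2c1)c1ccccc1` carries 7-chloro-1H-indazol-5-yl in place of 4-fluoro-1H-indazol-5-yl on a double-bonded chain carbon bound to an aromatic carbon and a double-bonded chain carbon. Among the measured compounds shown here, no measured step tests a chloro group, and no unsubstituted indazole is available to separate the ring from its substituent. The spread of compound 1, compound 2 and compound 3 suggests that moving a substituent around the indazole is not neutral, so a step beyond the scatter is expected in this assay, most likely toward a higher number. Compound 4 is therefore estimated at 30 nM, within 5 nM to 200 nM, which corresponds to an expected step of a 10-fold higher number from compound 3 to compound 4 (1.00 log units; beyond the scatter).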

Compound 4, half-maximal inhibitory concentration: 56 nM
For compound 4 the middle estimate is 1.9-fold (0.27 log units) below the measured one, and the stated range covers the measured number.
By their numbers in this assay, from the lowest: compound 3; then compounds 1 and 4 (each within the scatter of the next); then compound 2.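

In this assay the step of a 19-fold higher number from compound 3 to compound 4 (1.27 log units; beyond the scatter) shows that the low number of 4-fluoro-1H-indazol-5-yl does not carry over to 7-chloro-1H-indazol-5-yl. The step of an 8.4-fold lower number from compound 2 to compound 4 (0.92 log units; beyond the scatter) still sets the chloro group clearly apart from 6-methyl-1H-indazol-5-yl, while a 1.7-fold higher number from compound 1 to compound 4 (0.23 log units; within the scatter) leaves it without separation from the group carried by compound 1. No measurement available here speaks to why these steps arise.

The change from compound 3 to compound 4 alters both the halogen and its place on the indazole, so the two contributions cannot be read apart. Going by these compounds, whether the unsubstituted 1H-indazol-5-yl, or a methoxy or nitrile group in place of the chlorine, would fall nearer compound 3 or compound 2 remains open.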